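Methyl to isopropyl on the ring nitrogen of compound 2

The compounds below may be only part of what the source reports. "The series", "measured", "known", "first", "only" and "open" are said of these compounds alone.

Compound 1 `CN(C)c1nc2ccccn2c1-c1ccc(O)cc1` and compound 2 `CNc1nc2ccccn2c1-c1ccc(O)cc1` share one core. In an assay on isolated protein for inhibition of ubiquitin carboxyl-terminal hydrolase 47 (Homo sapiens) (a lower number here means a stronger inhibitor, a higher number a weaker inhibitor), compound 1 gives only the assay limit, > 100000 nM. In this assay compound 2 likewise gives only the limit, > 100000 nM. The step that the two limits leave unreadable from compound 1 to compound 2 is therefore not readable, since both values sit at the limit of > 100000 nM in this assay, at which 2 of the 2 values shown sit. Compound 3 `CC(C)Nc1nc2ccccn2c1-c1ccc(O)cc1` differs from compound 2 by isopropyl in place of methyl on a nitrogen on an aromatic ring. Within the data shown here, no measured step bears on this change, and compound 2 offers only a limit. Compound 3 is expected to remain near that limit, estimated at 150000 nM with a range from 50000 nM to 500000 nM. The expected step is a step that the limit leaves unreadable from compound 2 to compound 3.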

Compound 3, half-maximal inhibitory concentration: > 100000 nM
Compound 3 ended at the assay's limit; the forecaster's own chance of this, stated with the estimate: 85%; the middle value lies beyond the limit too.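

The steps among compound 1, compound 2 and compound 3 cannot be read, as all three stand at the assay's limit: the limit of > 100000 nM in this assay, at which 3 of the 3 values shown sit.

As far as these compounds go, whether any other group on this nitrogen gives a readable value in this assay stays open.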